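The source may hold more compounds than are shown below. What is called first, only, known or untested is meant among the compounds shown, and "the series" means these compounds.

Three compounds with a shared core have been run in a functional assay on the whole organism with Rattus norvegicus as the target, at a dose of 20 mg/kg by the oral route; on this read-out lower numbers stand for less inhibition and higher numbers for more inhibition at the one dose given (going by the name of the read-out). Compound 1 `NC(=O)/C=C1\CCc2c(F)cccc21` gives 40% in this assay. Compound 2 `O=C(/C=C1\CCc2ccc(F)cc21)NCCO` gives 42% in this assay, the largest of the three numbers, though the gap to compound 1 lies within the usual scatter, so these two cannot be told apart. Compound 3 `CNC(=O)/C=C1\CCc2ccc(Cl)cc21` gives 0% in this assay, a number far below the other two and well beyond the scatter. No two of these compounds differ in only one place, so none of the gaps can be tied to a single change.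

Compound 4 `O=C(/C=C1\CCc2ccc(F)cc21)N1CCCC1` has not yet been measured. It differs from compound 2 in a single place: pyrrolidin-1-yl in place of (2-hydroxyethyl)amino on a carbonyl carbon. Within the data shown here, since no pair of measured compounds shows what such a change at the carbonyl does on its own, the expectation here rests only on the spread of the three numbers. The expected step in this assay from compound 2 to compound 4 is a drop of moderate size, somewhat beyond the scatter, at a number 17 percentage points lower from compound 2 to compound 4 (beyond the scatter), because compound 3 with its own amide variation gives 0%. Compound 4 is therefore estimated at 25% in this assay, with a range from 0% to 55%.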

Compound 4, a percentage reported as inhibition, in the whole organism at one dose (the size of the read-out at that dose, not a potency): 10%
Compound 4: middle estimate off by 15 percentage points, on the high side, within the range that was stated.
By their numbers in this assay, from the lowest: compounds 3 and 4 (each within the scatter of the next); then compounds 1 and 2 (each within the scatter of the next).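

Among these compounds, compound 2 and compound 4 are the first pair here that differ in one place only, so a gap in this assay can now be tied to a single change: pyrrolidin-1-yl in place of (2-hydroxyethyl)amino on a carbonyl carbon gives a number 32 percentage points lower from compound 2 to compound 4 (beyond the scatter). With the rest of the structure held constant, the group on this carbonyl carbon clearly matters in this assay, although the swap alters several features at once, replacing an open chain with 2 hydrogen-bond donors and 1 hydrogen-bond acceptor by a five-membered ring with 0 of either. Nothing available explains why the number falls.

The pair cannot show whether the step follows the ring, the missing hydroxyl end of the chain or the missing amide hydrogen. An ethylamino group, which keeps the amide hydrogen without the hydroxyl, and a morpholin-4-yl group, which keeps a ring and adds an oxygen, would each separate these features on the same carbonyl carbon.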